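Swapping fluoro for nitro on a weak inhibitor

The compounds below may be only part of what the source reports. "The series", "measured", "known", "first", "only" and "open" are said of these compounds alone.

Measured in a functional assay on HCT-116 cells (Homo sapiens) for inhibition, read by CCK-8 assay, with a stated time of 48 h; a higher number here means a weaker inhibitor, a lower number a stronger inhibitor:
- Compound 1 `COc1cc(-c2ccnc3cc(-c4ccc(C)c(C)c4)nn23)cc(OC)c1OC`: 261 nM
- Compound 2 `COc1cc(-c2ccnc3cc(-c4cccc(C#N)c4)nn23)cc(OC)c1OC`: > 10000 nM, a limit of the assay
- Compound 3 `COc1ccc(-c2cc3nccc(-c4cc(OC)c(OC)c(OC)c4)n3n2)cc1F`: 2840 nM

Compound 3 holds the higher of the two true numbers. The gap is large: an 11-fold higher number from compound 1 to compound 3 (1.04 log units; beyond the scatter). Compound 4 `COc1ccc(-c2cc3nccc(-c4cc(OC)c(OC)c(OC)c4)n3n2)cc1[N+](=O)[O-]` carries nitro in place of fluoro on an aromatic carbon, ortho to a methoxy group (nitro in place of fluoro on an aromatic carbon). The other measured change away from 3,4-dimethylphenyl also raised the number: an at least 38-fold higher number from compound 1 to compound 2 (1.58 log units; beyond the scatter). Neither step involves nitro, so the guidance is only indirect. A modest further rise is expected from the nitrile example: an at least 3.5-fold lower number from compound 2 to compound 3 (0.54 log units; beyond the scatter). The expected change is a 1.8-fold higher number from compound 3 to compound 4 (0.25 log units; within the scatter). For compound 4 the estimated value is 5000 nM, with an expected range of 1500 nM to 10000 nM.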

Compound 4, half-maximal inhibitory concentration: > 10000 nM
Compound 4: a limit, no number; the forecaster's own chance of this, stated with the estimate: 30%; middle value at least 2.0-fold (0.30 log units) away from the limit.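

Earlier steps replaced the whole 3,4-dimethylphenyl group, whereas this one changes a single group, ortho to a methoxy group, and still gives an at least 3.5-fold higher number from compound 3 to compound 4 (0.54 log units; beyond the scatter). So in this assay, the fluoro position is not indifferent to what sits there, and nitro does not restore the strength of compound 1. Compound 4 gives a limit and not a number, so this step shows only a minimum size: the limit of > 10000 nM in this assay, at which 2 of the 4 values shown sit.

Going by these compounds, the true value of compound 4 stays open. So does the outcome with an amine or a hydroxyl group at this position.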